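The source may report more compounds than this note shows. Statements on the series, on what has been measured and on what is new or still open speak of the compounds shown alone.

Compounds measured so far:
Compound 1 `O=C1Nc2ccccc2/C1=N/NC(=S)Nc1ccccc1`: 1470 nM
Compound 2 `CC(C)c1ccc(NC(=S)N/N=C2\C(=O)Nc3ccccc32)cc1`: 1090 nM

Both values come from a functional assay on KB-V1 cells (Homo sapiens) for cytotoxicity, read by MTT assay, with a stated time of 72 h; a higher number here means a weaker inhibitor, a lower number a stronger inhibitor. With only these two measured, compound 2 stands level with compound 1, since their values lie within the scatter of each other. The next compound, compound 3 `CC(C)(C)c1ccc(NC(=S)N/N=C2\C(=O)Nc3ccccc32)cc1`, differs from compound 2 by one small change: methyl in place of hydrogen on a saturated chain carbon bound to an aromatic carbon and two saturated chain carbons. Methyl replaces hydrogen on a saturated chain carbon bound to an aromatic carbon and two saturated chain carbons, which turns isopropyl to tert-butyl. For the measured compounds named here, one measured step bears on this, a 1.3-fold lower number from compound 1 to compound 2 (0.13 log units; within the scatter). It placed isopropyl on an aromatic carbon of the same scaffold and stayed within the scatter. A single further methyl on that group therefore gives no reason to expect a shift in either direction in this assay beyond the scatter. The expected step is a 1.1-fold lower number from compound 2 to compound 3 (0.04 log units; within the scatter). For compound 3 the estimated value is 1000 nM, with an expected range of 500 nM to 2000 nM.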

Compound 3, half-maximal inhibitory concentration: 710 nM
Compound 3: middle estimate off by 1.4-fold (0.15 log units), on the high side, and the stated range covers the measured number.
By their numbers in this assay, from the lowest: compounds 3, 2 and 1 (each within the scatter of the next, the first and the last beyond it).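

In this assay, the further methyl on the isopropyl group keeps the pair within the scatter (a 1.5-fold lower number from compound 2 to compound 3 (0.19 log units; within the scatter)), so this single change shows no clear shift by itself. Taken whole, however, tert-butyl in place of hydrogen on an aromatic carbon is the first change among these compounds to pass beyond the scatter, though only modestly (a 2.1-fold lower number from compound 1 to compound 3 (0.32 log units; beyond the scatter)), which isopropyl in that place had not done. No measurement offered here accounts for this difference.

The compounds shown carry only hydrogen, isopropyl and tert-butyl at this place, so it stays open whether a methoxy group, a chlorine atom or a longer chain would give a similar number. All three also share the same core, so they do not tell whether the modest step would hold on a different one.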